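Exchanging an Ester-Bearing Chain for a Dichlorophenyl Ring

This account rests on a few compounds, and the source may have more. Where it says the series, first, only, none or still open, it means among the compounds named here.

Compound 1 `C=C(C)C(=O)N1N=C(c2ccc(-n3ccnc3)cc2)CC1c1ccc(N(C)C)cc1` and compound 2 `COC(=O)CC(=O)N1N=C(c2ccc(-n3ccnc3)cc2)CC1c1ccc(N(C)C)cc1` share one core. In a functional assay on NCI-H1975 cells (Homo sapiens) for inhibition, read by sulforhodamine B assay, tested at 10 uM (on this read-out higher numbers stand for more inhibition at the one concentration tested (going by the name of the read-out) and lower numbers for less inhibition), compound 1 gives -3.7% and compound 2 gives -0.1%. Among the two numbers shown, compound 2 stands level with compound 1, the step of a number 3.6 percentage points higher from compound 1 to compound 2 (within the scatter) being within the scatter. Compound 3 `CN(C)c1ccc(C2CC(c3ccc(-n4ccnc4)cc3)=NN2C(=O)c2cc(Cl)cc(Cl)c2)cc1` carries the change (3,5-dichlorophenyl in place of (methoxycarbonyl)methyl on a carbonyl carbon). Going by the values given here, only that one measured step bears on it, and it was small, so no step beyond the scatter is expected. Compound 3 is estimated at 5%, with a range from -10% to 25%. This means an expected step of a number 5.1 percentage points higher from compound 2 to compound 3 (within the scatter).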

Compound 3, a percentage reported as inhibition, at one concentration (the size of the read-out at that concentration, not a potency): 58.7%
The estimate for compound 3 lay 53.7 percentage points below the measured number; measured number above the stated range.
By their numbers in this assay, from the lowest: compounds 1 and 2 (each within the scatter of the next); then compound 3.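

The group on this carbonyl carbon can matter a great deal: in this assay, 3,5-dichlorophenyl gives a number 58.8 percentage points higher from compound 2 to compound 3 (beyond the scatter) and a number 62.4 percentage points higher from compound 1 to compound 3 (beyond the scatter). The earlier exchange between the two non-ring groups had shown no change beyond the scatter, so compound 3 is the first sign that this position responds at all. No measurement at hand explains the gain. The compounds shown leave open whether the aromatic ring alone or its two chlorine atoms carry this step; a plain phenyl or a cyclohexyl group on the same carbonyl carbon would help separate the two.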